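The source may report more compounds than this note shows. Statements on the series, on what has been measured and on what is new or still open speak of the compounds shown alone.

Measured compounds:
- compound 1 `CC(C)c1n[nH]c2c(NCc3ccc(-c4ccccn4)cc3)nc(SCC(O)CN3CCNCC3)nc12`: 332 nM
- compound 2 `CC(C)c1n[nH]c2c(NCc3ccc(-c4ccccn4)cc3)nc(SCC(O)CN)nc12`: 55 nM
- compound 3 `CC(C)c1n[nH]c2c(NCc3ccc(-c4ccccn4)cc3)nc(SC[C@H](O)CN)nc12`: 63 nM

All three were run in a functional assay on HT cells (Homo sapiens) for antiproliferative activity, read by fluorescence, with a stated time of 72 h; on this read-out lower numbers stand for stronger inhibition of growth and higher numbers for weaker inhibition of growth. Compound 1 stands highest of the three numbers; compound 3 lies nearest, a 5.3-fold lower number from compound 1 to compound 3 (0.72 log units; beyond the scatter), and compound 2 furthest, a 6.0-fold lower number from compound 1 to compound 2 (0.78 log units; beyond the scatter). Between compounds 2 and 3 the gap is a 1.1-fold higher number from compound 2 to compound 3 (0.06 log units; within the scatter), which fits (the fact that one of compounds 2 and 3 is drawn with a defined configuration and the other without, at the place where they differ).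

Compound 4 `CNCCSc1nc(NCc2ccc(-c3ccccn3)cc2)c2[nH]nc(C(C)C)c2n1` is still to be measured in this assay. It differs from compound 1 as follows: (methylamino)methyl in place of 1-hydroxy-2-(piperazin-1-yl)ethyl on a saturated chain carbon bound to a sulfur. Within the data shown here, both measured steps from compound 1 exchange the piperazin-1-yl end for a plain amine and lower the number modestly; compound 4 makes a related exchange but also loses the hydroxy, a change no measured pair covers. A step down of similar size is expected, a 3.9-fold lower number from compound 1 to compound 4 (0.59 log units; beyond the scatter), so compound 4 is estimated at 85 nM, within 30 nM to 250 nM.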

Compound 4, concentration for 50% growth inhibition: 56 nM
The estimate for compound 4 lay 1.5-fold (0.18 log units) above the measured number; measured number inside the range.
By their numbers in this assay, from the lowest: compounds 2, 4 and 3 (each within the scatter of the next); then compound 1.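

The hydroxy is not needed to keep the number low at this place: the exchange of 1-hydroxy-2-(piperazin-1-yl)ethyl for (methylamino)methyl gives a 5.9-fold lower number from compound 1 to compound 4 (0.77 log units; beyond the scatter) in this assay, with no hydroxy left on the chain. Against the 2-amino-1-hydroxyethyl chains, (methylamino)methyl shows a 1.1-fold lower number from compound 3 to compound 4 (0.05 log units; within the scatter) and a 1.0-fold higher number from compound 2 to compound 4 (0.01 log units; within the scatter), so the shorter, methylated chain without hydroxy cannot be told apart from them. Nothing given here offers a cause for this result.

The compounds shown hold no pair that differs in the hydroxy alone. Going by these compounds, how a dimethylamino end or a longer chain would read at this place stays open.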